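Phenyl in Place of an Alkenyl Chain on Compound 1

A few compounds are considered here, and "the series" means these few. Any claim that something is new, unique, unknown or untested is made for them only; others in the source may bear on it.

Compound 1 `COc1ccnc(Nc2ccc(Cl)c(OCC=C(C)C)c2)n1` gives the highest of the three measured numbers in an ADME assay on MT2 cells (Homo sapiens) for cytotoxicity (on this read-out higher numbers stand for lower toxicity in this test and lower numbers for higher toxicity in this test), at 9000 nM. Compound 2 `CC(C)=CCOc1cc(Nc2nccc(N)n2)ccc1Cl` gives 500 nM, and compound 3 `CNc1ccnc(Nc2ccc(Cl)c(OCC=C(C)C)c2)n1` gives 690 nM. The measured steps read an 18-fold lower number from compound 1 to compound 2 (1.26 log units; beyond the scatter) and a 13-fold lower number from compound 1 to compound 3 (1.12 log units; beyond the scatter), while a 1.4-fold higher number from compound 2 to compound 3 (0.14 log units; within the scatter). Compound 4 `COc1ccnc(Nc2ccc(Cl)c(Oc3ccccc3)c2)n1` differs from compound 1 by phenyl in place of 3-methylbut-2-en-1-yl on an oxygen on an aromatic ring. Going by the values given here, every measured step alters the group on an aromatic carbon of the shared core, so none of them touches the oxygen where this change sits, and no step bears on it directly. With nothing pointing in either direction, the expected step is a 1.1-fold lower number from compound 1 to compound 4 (0.05 log units; within the scatter), within the scatter. Compound 4 is estimated at 8000 nM in this assay, in a range from 2500 nM to 25000 nM.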

Compound 4, half-maximal cytotoxic concentration: 38000 nM
Compound 4: the middle estimate sits 4.8-fold (0.68 log units) below what was measured; measured number outside the range, above it.
By their numbers in this assay, from the lowest: compounds 2 and 3 (each within the scatter of the next); then compound 1; then compound 4.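

Going by these compounds alone, with a 4.2-fold higher number from compound 1 to compound 4 (0.63 log units; beyond the scatter) in this assay, the group on the oxygen proves able to shift this number, which the earlier steps on an aromatic carbon of the shared core could not show. Phenyl in place of 3-methylbut-2-en-1-yl moves toward lower toxicity in this test, the opposite direction to both large steps away from compound 1. Nothing available here explains this rise. Still open, on these data alone, is how benzyl or a chlorine-bearing phenyl would behave on this oxygen. Also open, as far as these compounds go, is whether phenyl gives the same step when amino replaces methoxy on the core.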